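Moving the Phenyl Closer to Sulfur on a Second Core

This account rests on a few compounds, and the source may have more. Where it says the series, first, only, none or still open, it means among the compounds named here.

Compound 1 `Cc1cc(-n2cccc2)cn2c(CSCCc3ccccc3)cnc12` gives 11 ug/mL.
Compound 2 `Cc1cc(-n2cccc2)cn2c(CSCc3ccccc3)cnc12` gives 17 ug/mL.
Compound 3 `Cc1cc(-n2cccc2)c2ncc(CSCCc3ccccc3)n2c1` gives 26 ug/mL.

All three were tested in an ADME assay on HEL cells (Homo sapiens) for cytotoxicity, with a stated time of 3 days; on this read-out higher numbers stand for lower toxicity in this test and lower numbers for higher toxicity in this test. Compound 1 and compound 2 share one core and differ by phenyl in place of benzyl on a saturated chain carbon bound to a sulfur; that change gave a 1.5-fold higher number from compound 1 to compound 2 (0.19 log units; within the scatter). Compound 3 is built from the same atoms as compound 1, joined differently; the difference between the two cores is not broken down here. Compound 4 `Cc1cc(-n2cccc2)c2ncc(CSCc3ccccc3)n2c1` stands to compound 3 as compound 2 stands to compound 1: it differs by phenyl in place of benzyl on a saturated chain carbon bound to a sulfur, the same change at the same place. Among the measured compounds shown here, the step from compound 3 to compound 4 is expected to be a 1.3-fold higher number from compound 3 to compound 4 (0.13 log units; within the scatter), resting on the one earlier step of a 1.5-fold higher number from compound 1 to compound 2 (0.19 log units; within the scatter) on the other core. Compound 4 is therefore expected to give about 35 ug/mL, somewhere between 15 ug/mL and 80 ug/mL.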

Compound 4, half-maximal cytotoxic concentration: 15 ug/mL
Estimate against measurement, compound 4: 2.3-fold (0.37 log units) above, and the stated range covers the measured number.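

In this assay, the new step reads a 1.7-fold lower number from compound 3 to compound 4 (0.24 log units; within the scatter). Each step on its own stays within the usual scatter, yet the two steps run in opposite directions and the gap between them does not: the same change on two cores in this assay, a 1.5-fold higher number (0.19 log units; within the scatter) from compound 1 to compound 2 and a 1.7-fold lower number (0.24 log units; within the scatter) from compound 3 to compound 4, 2.7-fold (0.43 log units) apart, beyond the scatter of two such steps. On these two pairs, then, the change did not carry over from the core of compound 1 to the core of compound 3 with the same size or direction, but one pair per core cannot show why this happens or how general it is.

The compounds shown leave open what happens when an amine, a carboxylic acid or a chain longer than phenethyl takes the place of the benzyl or phenethyl group. On these data alone, whether the two cores would also part ways with those groups remains open too.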